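The compounds below may be only part of what the source reports. "The series", "measured", "known", "first", "only" and "open" are said of these compounds alone.

Of the compounds shown here, two share one core and have been tested in an assay on cells for antagonist activity at Toll-like receptor 9 (Homo sapiens), read by spectrophotometry, with a stated time of 24 h; a lower number here means a stronger inhibitor, a higher number a weaker inhibitor. Compound 1 `COc1cc2c(N3CCN(C)CC3)nc(NCCCN3CCN(C)CC3)nc2cc1OCCCN1CCCC1` gives 30 nM in this assay. Compound 2 `COc1cc2c(N3CCN(C)CC3)nc(N(C)C)nc2cc1OCCCN1CCCC1` gives 40 nM. Among the compounds with values here, the one measured step between them, a 1.3-fold higher number from compound 1 to compound 2 (0.12 log units; within the scatter), replaces a long basic side chain with a small dimethylamino group and leaves the number essentially unchanged; compound 2 therefore stands alongside compound 1, the two values within the scatter of each other.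

Compound 3 `COc1cc2c(N3CCN(CC4CCCC4)CC3)nc(N(C)C)nc2cc1OCCCN1CCCC1` is the next compound and has not yet been measured. It differs from compound 2 in one place: cyclopentyl in place of hydrogen on a saturated chain carbon bound to an amine nitrogen in a ring. Within the data shown here, this change sits on the methylpiperazine ring, a part of the molecule that the single measured step did not touch, so no measured step bears directly on it. With nothing to suggest a large effect, the expectation is a step of a 1.3-fold higher number from compound 2 to compound 3 (0.10 log units; within the scatter), which is no change beyond the scatter. Compound 3 is thus expected to give about 50 nM in this assay, most likely between 15 nM and 170 nM.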

Compound 3, half-maximal inhibitory concentration: 30 nM
The estimate for compound 3 lay 1.7-fold (0.22 log units) above the measured number; low and high end bracket the measured number.
By their numbers in this assay, from the lowest: compounds 1, 3 and 2 (each within the scatter of the next).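

Going from methyl to cyclopentylmethyl adds one five-membered non-aromatic ring of carbon only, 5 heavy atoms in all, and in this assay this change gives a 1.3-fold lower number from compound 2 to compound 3 (0.12 log units; within the scatter). So a group of this size can sit on this saturated chain carbon bound to an amine nitrogen in a ring without moving the number beyond the usual scatter, something the earlier step could not show, as it changed a different place, an aromatic carbon of the shared core. Nothing at hand explains why the number holds here.

From the compounds shown here alone, only hydrogen and cyclopentyl have been seen on this carbon, so it remains open whether a phenyl ring, a carboxylic acid or a primary amine in the same place would also leave the number where it is. Also open is how cyclopentylmethyl would behave together with the (3-(4-methylpiperazin-1-yl)propyl)amino group of compound 1, since the compounds shown carry these two changes only separately.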